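Swapping Trifluoromethyl for Fluoro on a Diarylurea Series

The source may report more compounds than this note shows. Statements on the series, on what has been measured and on what is new or still open speak of the compounds shown alone.

Of the compounds shown here, three sharing one core have been measured. In a functional assay on NCI-H226 cells (Homo sapiens) for inhibition, read by MTT assay, with a stated time of 48 h, tested at 10 uM (on this read-out lower numbers stand for less inhibition and higher numbers for more inhibition at the one concentration tested (going by the name of the read-out)), compound 1 `COc1cc(NC(=O)Nc2cc(Nc3ccc(OC)c(I)c3)ncn2)cc(OC)c1` gives 40.1%, compound 2 `COc1cc(NC(=O)Nc2cc(Nc3ccc(Br)cc3OC)ncn2)cc(OC)c1` gives 25.7%, and compound 3 `COc1cc(NC(=O)Nc2cc(Nc3cc(C(F)(F)F)ccc3OC)ncn2)cc(OC)c1` gives 60%, the highest of the three and beyond the scatter from both others. Among the compounds with values here, the only step between measured compounds is a number 14.4 percentage points lower from compound 1 to compound 2 (beyond the scatter). Compound 4 `COc1cc(NC(=O)Nc2cc(Nc3cc(F)ccc3OC)ncn2)cc(OC)c1` differs from compound 3 by fluoro in place of trifluoromethyl on an aromatic carbon. Within the data shown here, no measured step changes just this group, so the one known step offers only a rough sense of how far changes on that aryl ring move the read-out. A modest drop is therefore expected, a number 15 percentage points lower from compound 3 to compound 4 (beyond the scatter), with wide uncertainty. Compound 4 is estimated to give 45%, within 25% to 65%.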

Compound 4, a percentage reported as inhibition, at one concentration (the size of the read-out at that concentration, not a potency): 37.7%
Compound 4: middle estimate off by 7.3 percentage points, on the high side; the range from low to high includes it.
By their numbers in this assay, from the lowest: compound 2; then compounds 4 and 1 (each within the scatter of the next); then compound 3.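

In this assay this one-group change gives a number 22.3 percentage points lower from compound 3 to compound 4 (beyond the scatter) and so shows that the read-out depends on which group sits on this aromatic carbon. Among whole aryl swaps, a number 12 percentage points higher from compound 2 to compound 4 (beyond the scatter) stands against a number 2.4 percentage points lower from compound 1 to compound 4 (within the scatter) so the aryl groups of those last two compounds cannot be told apart here. No measurement at hand explains these differences. On these data alone, whether a nitrile or a chloro group at the same place would give a number nearer compound 3 or compound 4 stays open.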